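The source may hold more compounds than are shown below. What is called first, only, known or untested is meant among the compounds shown, and "the series" means these compounds.

Two measured compounds frame this account. Compound 1 `COc1ccc(CS(=O)(=O)/C=C/c2ccc(OC)c(OC)c2OC)cc1[N+](=O)[O-]` carries a nitro group on one aromatic ring and a trimethoxy-substituted vinyl sulfone on the other. In an ADME assay on MRC5 cells (Homo sapiens) for cytotoxicity, read by MTT assay, with a stated time of 72 h (a higher number here means a weaker inhibitor of growth, a lower number a stronger inhibitor of growth), compound 1 reaches only the limit of the assay, reported as > 30000 nM, so its exact position is not known and it sits at the limit of > 30000 nM in this assay, at which 1 of the 2 values shown sits. Among the measured compounds shown here, compound 2 `COc1ccc(CS(=O)(=O)CC(=O)Nc2c(C)cc(C)cc2C)cc1[N+](=O)[O-]`, which replaces the vinyl arm with an amide to a trimethylated aniline, is the only one with a number: in this assay compound 2 gives 28000 nM. Both compounds therefore stand at the weak end of growth inhibition.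

The step under consideration leads to compound 3 `COc1ccc(CS(=O)(=O)/C=C/c2ccc(OC)c(OC)c2OC)cc1N`. The change is amino in place of nitro on an aromatic carbon, in words amino in place of nitro on an aromatic carbon, on the ring ortho to a methoxy group and meta to a large group. For the measured compounds named here, no measured pair separates these two groups here, so nothing in the data indicates how far the swap should move the read-out. The reasonable expectation is a step of a number no higher from compound 1 to compound 3 (the limit leaves the size open) that stays within the scatter, with compound 3 estimated at 30000 nM, between 8000 nM and 60000 nM, and a fair chance that the assay again reports only a limit.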

Compound 3, concentration for 50% growth inhibition: > 30000 nM
Compound 3 gave a limit, no number; the forecaster's own chance of this, stated with the estimate: 50%; the middle value sits exactly at the limit.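

In this assay compound 3 gives > 30000 nM, which is a limit and not a number, and compound 1 also stands only at a limit, so no step can be read between compound 1 and compound 3: the limit of > 30000 nM in this assay, at which 2 of the 3 values shown sit.

The compounds shown leave open whether amino in place of nitro on an aromatic carbon moves growth inhibition at all, and in which direction.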